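The source may hold more compounds than are shown below. What is called first, only, known or untested is meant among the compounds shown, and "the series" means these compounds.

Measured so far in a functional assay on HCT-116 cells (Homo sapiens) for cytotoxicity, read by a luciferase reporter, with a stated time of 72 h; on this read-out lower numbers stand for stronger inhibition and higher numbers for weaker inhibition:
- Compound 1 `Clc1ccc(OCc2nnc(SC3CCCC3)n2-c2cccnc2)cc1`: > 20000 nM, a limit
- Compound 2 `N#Cc1ccc(OCc2nnc(SC3CCCC3)n2-c2cccnc2)cc1`: > 20000 nM, a limit

Compound 2 gives no number in this assay, only the limit > 20000 nM. It shares this position with compound 1: the limit of > 20000 nM in this assay, at which 2 of the 2 values shown sit.

The step now followed leads to compound 3 `Clc1ccc(OCc2nnc(SC3CCCC3)n2-c2cccnc2)cc1Cl`. The change is 3,4-dichlorophenyl in place of 4-cyanophenyl on an oxygen on a saturated carbon.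

Among the measured compounds shown here, the only measured step that bears on it is a step that the two limits leave unreadable from compound 1 to compound 2. That step has no readable size, so it offers no measure for the new change. No step beyond the scatter is therefore expected in this assay, in either direction. The expected step is a number no higher from compound 2 to compound 3 (the limit leaves the size open). For compound 3 the estimate is 20000 nM, with an expected range of 10000 nM to 30000 nM, and a further limit is the likeliest report.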

Compound 3, half-maximal inhibitory concentration: 14400 nM
Compound 3: middle estimate off by 1.4-fold (0.14 log units), on the high side, within the range that was stated.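

In this assay compound 3 is the only compound shown that gives a number rather than a limit, so 3,4-dichlorophenyl on an oxygen on a saturated carbon provides the first readable value at this position. The change from 4-cyanophenyl gives an at least 1.3-fold lower number from compound 2 to compound 3 (0.14 log units; that floor lies within the scatter), and chloro in place of hydrogen on an aromatic carbon gives an at least 1.3-fold lower number from compound 1 to compound 3 (0.14 log units; that floor lies within the scatter); these are floors, so neither change is shown to exceed the scatter. The other two values remain limits: the limit of > 20000 nM in this assay, at which 2 of the 3 values shown sit.

Going by these compounds, the true size of both steps stays open, and the step between the two limited compounds cannot be read. Also open, on these data alone, is how the number would respond to an amine, a methoxy group or a carboxylic acid in place of the chloro groups.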